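A nitro swap at the edge of the assay

A few compounds are considered here, and "the series" means these few. Any claim that something is new, unique, unknown or untested is made for them only; others in the source may bear on it.

Measured so far in a functional assay on A549 cells (Homo sapiens) for antiproliferative activity, read by MTT assay, with a stated time of 48 h; on this read-out lower numbers stand for stronger inhibition and higher numbers for weaker inhibition:
Compound 1 `C/C(=C\CC/C(C)=C/CC[C@@H]1[C@@]2(C)CCC(=O)C(C)(C)[C@H]2CC[C@@]1(C)O)CC/C=C(\C)C(=O)OCc1cn(-c2ccc(F)cc2)nn1` gives > 150000 nM (a limit)
Compound 2 `C/C(=C\CC/C(C)=C/CC[C@@H]1[C@@]2(C)CCC(=O)C(C)(C)[C@H]2CC[C@@]1(C)O)CC/C=C(\C)C(=O)OCc1cn(-c2ccccc2C(F)(F)F)nn1` gives > 150000 nM (a limit)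

Compound 2 stands at > 150000 nM as a limit, and no number is known for it. The evidence so far is the limit of > 150000 nM in this assay, at which 2 of the 2 values shown sit, and nothing more. Going by the values given here, the one measured step is a step that the two limits leave unreadable from compound 1 to compound 2 and gives no size to carry forward. Compound 3 `C/C(=C\CC/C(C)=C/CC[C@@H]1[C@@]2(C)CCC(=O)C(C)(C)[C@H]2CC[C@@]1(C)O)CC/C=C(\C)C(=O)OCc1cn(-c2ccccc2[N+](=O)[O-])nn1` differs from compound 2 by nitro in place of trifluoromethyl on an aromatic carbon. No step beyond the scatter is therefore expected in this assay and another limit is the likeliest result. The estimated step is a number no higher from compound 2 to compound 3 (the limit leaves the size open) in size. For compound 3 the expected value is 150000 nM within an estimated range from 50000 nM to 300000 nM in this read-out.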

Compound 3, half-maximal inhibitory concentration: > 150000 nM
Compound 3 was reported as a limit; the forecaster's own chance of this, stated with the estimate: 75%; the middle value lies on the limit itself.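

Going by these compounds alone, compound 1, compound 2 and compound 3 all stand as limits in this assay, and no step between them can be read. The compounds shown leave open whether the three differ at all: none has an actual number.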